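This account rests on a few compounds, and the source may have more. Where it says the series, first, only, none or still open, it means among the compounds named here.

Measured so far in a functional assay on WiDr cells (Homo sapiens) for inhibition; on this read-out higher numbers stand for weaker inhibition and lower numbers for stronger inhibition:
compound 1 `CNC(=O)N1CC1C#N` gives 21000 nM
compound 2 `N#CC1CN1C(=O)NC1CCCCC1` gives 2400 nM
compound 3 `N#CC1CN1C(=O)Nc1cccc2ccccc12` gives 2400 nM

Compound 1 has the highest number of the three in this assay. Compound 2 and compound 3 each lie below it by the same margin, and that margin is beyond the scatter, so compound 1 is the weakest inhibitor of the set. Between compound 2 and compound 3 nothing separates the two values.

Compound 4 `N#CC1CN1C(N)=O` has not yet been measured. It differs from compound 1 by hydrogen in place of methyl on an amide-type nitrogen; cut one bond further out, the methylamino becomes amino. Going by the values given here, no pair of measured compounds differs in only one place, so no step of this kind has been observed. What the measured set does show is that compound 1, which carries the smallest group on the amide-type nitrogen, is also the weakest of the three, and compound 4 carries an even smaller one. On that basis the step toward compound 4 is expected to go to a higher number, probably beyond the scatter, though a result within the scatter of compound 1 cannot be ruled out. The step expected is a 2.1-fold higher number from compound 1 to compound 4 (0.33 log units; beyond the scatter). For compound 4 the estimated value in this assay is 45000 nM, with a range from 15000 nM to 120000 nM.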

Compound 4, half-maximal inhibitory concentration: > 280000 nM
Compound 4 gave a limit, no number (the forecaster's own chance of this, stated with the estimate: 25%); middle value at least 6.2-fold (0.79 log units) from the limit.
By their numbers in this assay, from the lowest: compounds 2 and 3 (each within the scatter of the next); then compound 1. At a limit, above all of these: compound 4.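

Going by these compounds alone, this is the first one-place step read, and it shows that the methyl on this amide-type nitrogen matters to the read-out: in this assay, hydrogen in place of methyl gives an at least 13-fold higher number from compound 1 to compound 4 (1.12 log units; beyond the scatter). Compound 4 stands at > 280000 nM, which is a limit and not a number. The step therefore gives only a minimum size, and its true size stays unknown because the value of compound 4 is a limit: the limit of > 280000 nM in this assay, at which 1 of the 4 values shown sits.

Open is how the read-out in this assay moves along a graded series on this nitrogen, for example with ethyl, propyl or a longer straight chain, as the compounds shown offer no one-place step from methyl to any larger group. Also open, on these data alone, is whether a chain on this nitrogen ending in an amine or a carboxylic acid would keep inhibition, and whether a simple phenyl would read differently from the larger ring groups of compound 2 and compound 3.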